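The compounds below may be only part of what the source reports. "The series", "measured", "known", "first", "only" and "open" are said of these compounds alone.

Compound 1 `N#C/C(=C\c1ccccc1OS(=O)(=O)c1ccc(Cl)cc1)C(=O)Nc1nnc(Cc2ccc(F)cc2)s1` gives 6%
Compound 2 `N#C/C(=C\c1ccccc1OS(=O)(=O)c1ccccc1[N+](=O)[O-])C(=O)Nc1nnc(Cc2ccc(Cl)cc2)s1` gives 20%

Only these two compounds have been measured so far in an ADME assay on HEK-293T cells (Homo sapiens) for inhibition, read by CCK-8 assay, with a stated time of 48 h, tested at 20 uM (on this read-out higher numbers stand for more inhibition of growth at the one concentration tested and lower numbers for less inhibition of growth), and they differ in more than one place. Compound 2 stands the higher of the two, at 20% on this scale, and its gap to compound 1 lies beyond the scatter. Compound 3 `N#C/C(=C\c1ccccc1OS(=O)(=O)c1ccc(Cl)cc1)C(=O)Nc1nnc(Cc2ccc(Cl)cc2)s1` keeps the rest of compound 2 and changes one group: 4-chlorophenyl in place of 2-nitrophenyl on a sulfonyl sulfur is the whole difference, 4-chlorophenyl in place of 2-nitrophenyl on a sulfonyl sulfur. Among the compounds with values here, no measured pair isolates this change, so the expectation rests on thin evidence. Compound 1, which also carries 4-chlorophenyl on its sulfonyl sulfur, gives 6% in this assay and that points to a modest fall rather than a rise. The expected change is a number 7 percentage points lower from compound 2 to compound 3 (within the scatter) and this estimated fall would stay within the scatter. Compound 3 is expected to read 13% with 3% to 27% as the estimated range.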

Compound 3, percent growth inhibition at one concentration: 14%
Compound 3: middle estimate off by 1 percentage points, on the low side, within the range that was stated.
By their numbers in this assay, from the lowest: compounds 1, 3 and 2 (each within the scatter of the next, the first and the last beyond it).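

The sulfonyl sulfur now has a pair that isolates a single change in this assay: 4-chlorophenyl in place of 2-nitrophenyl gives a number 6 percentage points lower from compound 2 to compound 3 (within the scatter), so this comparison does not separate the two groups. The same compound also gives a second single-place comparison, away from the sulfonyl sulfur, where chloro in place of fluoro on an aromatic carbon gives a number 8 percentage points higher from compound 1 to compound 3 (within the scatter), so neither change taken alone stands clear of the usual variation between repeated measurements. Nothing available on these compounds accounts for either reading.

Going by these compounds, it remains open whether a different group on the sulfonyl sulfur, such as 4-aminophenyl, 4-carboxyphenyl or a plain methyl, would move the reading in this assay beyond the scatter, or whether these two groups would differ clearly on another version of the core. On these data alone, it is equally open whether a methoxy group or a bromine atom in place of the chloro or fluoro on that aromatic carbon would produce a step that can be told apart from the scatter.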